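This account rests on a few compounds, and the source may have more. Where it says the series, first, only, none or still open, it means among the compounds named here.

Compound 1 `COc1ccc(/C=N/NC(=O)Nc2ccc(Oc3ccnc4cc(OCCCN5CCCCC5)c(OC)cc34)c(F)c2)cc1` in a functional assay on HT-29 cells (Homo sapiens) for cytotoxicity, read by MTT assay, with a stated time of 72 h (on this read-out higher numbers stand for weaker inhibition and lower numbers for stronger inhibition), gives 590 nM. Compound 2 `COc1cc2c(Oc3ccc(NC(=O)N/N=C/c4ccc(F)cc4Cl)cc3F)ccnc2cc1OCCCN1CCCCC1` gives 260 nM. Compound 3 `COc1cc2c(Oc3ccc(NC(=O)N/N=C/c4ccncc4)cc3F)ccnc2cc1OCCCN1CCCCC1` gives 940 nM.

Compound 2 stands with the lowest of the three numbers, and its steps to compound 1 and to compound 3 are both beyond the scatter. Compound 4 `COc1cc2c(Oc3ccc(NC(=O)N/N=C/c4cc5ccccc5[nH]4)cc3F)ccnc2cc1OCCCN1CCCCC1` differs from compound 2 by 1H-indol-2-yl in place of 2-chloro-4-fluorophenyl on a carbon with a double bond to nitrogen. Two measured steps alter the same group on the same carbon: a 2.3-fold lower number from compound 1 to compound 2 (0.36 log units; beyond the scatter) and a 3.6-fold higher number from compound 2 to compound 3 (0.56 log units; beyond the scatter). In both, the 2-chloro-4-fluorophenyl carries the lower number, and each departure from it is a modest change. A modest step toward a higher number is therefore expected, a 2.3-fold higher number from compound 2 to compound 4 (0.36 log units; beyond the scatter). In this assay compound 4 is estimated at 600 nM, with a range from 200 nM to 1800 nM.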

Compound 4, half-maximal inhibitory concentration: 820 nM
For compound 4 the middle estimate is 1.4-fold (0.14 log units) below the measured one; the range from low to high includes it.
By their numbers in this assay, from the lowest: compound 2; then compounds 1, 4 and 3 (each within the scatter of the next).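

In this assay the 1H-indol-2-yl group, which brings a second aromatic ring and a hydrogen-bond donor to this carbon, shows a 3.2-fold higher number from compound 2 to compound 4 (0.50 log units; beyond the scatter) as a further departure from 2-chloro-4-fluorophenyl. With a 1.1-fold lower number from compound 3 to compound 4 (0.06 log units; within the scatter) and a 1.4-fold higher number from compound 1 to compound 4 (0.14 log units; within the scatter) as well, compound 4 does not separate from the pyridin-4-yl and 4-methoxyphenyl compounds, so only 2-chloro-4-fluorophenyl stands apart among the four groups. Nothing measured here says why it stands apart.
Still open, on these data alone, is whether a phenyl bearing only chloro or only fluoro would match 2-chloro-4-fluorophenyl, and how an aliphatic amine or a carboxylic acid on the aromatic ring would compare.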